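The source may hold more compounds than are shown below. What is called first, only, known or untested is meant among the compounds shown, and "the series" means these compounds.

Measured in a functional assay on the whole organism (strain albino) for inhibition, with Rattus norvegicus as the target, read by paw edema, with a stated time of 1 h, at a dose of 100 mg/kg by the oral route; on this read-out higher numbers stand for more inhibition at the one dose given (going by the name of the read-out) and lower numbers for less inhibition:
- compound 1 , `N#Cc1c(-c2ccc(Cl)cc2)nc(SCC(=O)Nn2c(COc3ccc(Cl)cc3Cl)nc3ccccc3c2=O)[nH]c1=O`: 63.6%
- compound 2 , `N#Cc1c(-c2ccc(O)cc2)nc(SCC(=O)Nn2c(COc3ccc(Cl)cc3Cl)nc3ccccc3c2=O)[nH]c1=O`: 63.6%
- compound 3 , `N#Cc1c(Cl)nc(SCC(=O)Nn2c(COc3ccc(Cl)cc3Cl)nc3ccccc3c2=O)nc1-c1ccc(Cl)cc1`: 63.6%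

Compound 1 and compound 2 share one core. The change between them is hydroxy in place of chloro on an aromatic carbon, and the step it made in this assay is no change at the digits printed from compound 1 to compound 2 (within the scatter). Compound 3 carries a different core; the difference between the two cores is not broken down here. In this assay compound 3 stands level with compound 1 and with compound 2 at the digits given, within the scatter of both.

Compound 4 , `N#Cc1c(Cl)nc(SCC(=O)Nn2c(COc3ccc(Cl)cc3Cl)nc3ccccc3c2=O)nc1-c1ccc(O)cc1`, is not yet measured. Within the data shown here, it arises from compound 3 by hydroxy in place of chloro on an aromatic carbon, the same change as the one made from compound 1 to compound 2 , at the same place on the ring. For compound 4 the expected step in this assay is no change at the digits printed from compound 3 to compound 4 (within the scatter), resting on the earlier step of no change at the digits printed from compound 1 to compound 2 (within the scatter), which stayed within the scatter, and on the level at which compound 1 and compound 3 sit, compound 3 giving 63.6%. Compound 4 is thus estimated at 63.6% in this assay, with a range from 53% to 73%.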

Compound 4, a percentage reported as inhibition, in the whole organism at one dose (the size of the read-out at that dose, not a potency): 72.7%
Compound 4: the middle estimate sits 9.1 percentage points below what was measured, and the stated range covers the measured number.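

In this assay the change from 4-chlorophenyl to 4-hydroxyphenyl gives a number 9.1 percentage points higher from compound 3 to compound 4 (within the scatter), and set beside the earlier step, the two cores do not separate: the same change on two cores in this assay, no change at the digits printed (within the scatter) from compound 1 to compound 2 and a number 9.1 percentage points higher (within the scatter) from compound 3 to compound 4, 9.1 percentage points apart, within the scatter of two such steps. On these two cores, then, hydroxy in place of chloro carries over with no step beyond the scatter, so the flat result on the first core is a fair guide to the second. Among these compounds, this rests on only two pairs at a single dose and a single time, so it does not show that compound 4 differs from compound 3, says nothing about potency, and does not establish that the change would stay within the scatter on any other core.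

The compounds shown leave open whether an amine, a methoxy group or a carboxylic acid at the same place on the ring would hold the same level. Also open, going by these compounds, is whether the two cores would stay together at other doses or times.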